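The compounds below may be only part of what the source reports. "The series", "measured", "known", "first", "only" and "open" are said of these compounds alone.

Compound 1, `COc1cc(C)cc(-c2c(-c3ccnc(-c4ccc(N(C)C)cc4)c3)cnn2CC#N)c1`: -26%
Compound 2, `COc1cc(C)cc(-c2nn(CC#N)cc2-c2ccnc(-c3ccc(N(C)C)cc3)c2)c1`: -13%

In a functional assay on HOP-92 cells (Homo sapiens) for cytotoxicity, read by sulforhodamine B assay, with a stated time of 48 h, tested at 10 uM (a lower number here means a stronger effect, a higher number a weaker effect of the compound at the concentration tested), compound 1 gives the lower of the two numbers; compound 2 sits higher by an amount beyond the usual scatter of such measurements. Compound 3, `COc1cc(C)cc(-c2c(-c3ccnc(-c4ccc(C(C)=O)cc4)c3)cnn2CC#N)c1`, has not yet been measured. It differs from compound 1 in a single place: acetyl in place of dimethylamino on an aromatic carbon. Within the data shown here, no measured pair shows this particular change, so its effect is not known from these data. Only a small step, if any, toward a weaker effect is expected, a number 11 percentage points higher from compound 1 to compound 3 (beyond the scatter). Compound 3 is accordingly estimated at -15%, within a range from -35% to 5%.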

Compound 3, a percentage reported as activity, at one concentration (the size of the read-out at that concentration, not a potency): -1%
The estimate for compound 3 lay 14 percentage points below the measured number; low and high end bracket the measured number.
By their numbers in this assay, from the lowest: compound 1; then compound 2; then compound 3.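

Acetyl in place of dimethylamino on this aromatic carbon, para to a large group, gives in this assay a number 25 percentage points higher from compound 1 to compound 3 (beyond the scatter) and so shows that the effect at this position depends on which group sits there. The count does not separate the two groups, as each has 3 heavy atoms and 1 hydrogen-bond acceptor. No measurement here explains the step. Going by these compounds, whether an amino group or a carboxylic acid at this position would match dimethylamino or acetyl stays open. So does whether the same change would act alike on compound 2.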